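The source may hold more compounds than are shown below. What is called first, only, known or untested is meant among the compounds shown, and "the series" means these compounds.

Measured in a functional assay on A549 cells (Homo sapiens) for antiproliferative activity, read by MTT assay, with a stated time of 48 h; on this read-out higher numbers stand for weaker inhibition and lower numbers for stronger inhibition:

Compound 1 `Cn1cc(C2=C(c3nn(CCCn4ccnc4)c4ncccc34)C(=O)NC2=O)c2ccccc21`: > 100000 nM
Compound 2 `Cn1cc(C2=C(c3nn(CCn4ccnc4)c4ncccc34)C(=O)NC2=O)c2ccccc21`: > 100000 nM

Both entries are limits of the assay and not numbers. Compound 2 has only the limit > 100000 nM, so it offers no exact starting value. The next compound is compound 3 `Cn1cc(C2=C(c3nn(CCCO)c4ncccc34)C(=O)NC2=O)c2ccccc21`, and the change is hydroxymethyl in place of 1H-imidazol-1-yl on a saturated chain carbon, two bonds along the chain from an aromatic nitrogen. In words, hydroxymethyl takes the place of 1H-imidazol-1-yl on a saturated chain carbon, two bonds along the chain from an aromatic nitrogen. Cut one bond further out, 2-(1H-imidazol-1-yl)ethyl gives way to 3-hydroxypropyl.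

Within the data shown here, only one measured step bears on this: a step that the two limits leave unreadable from compound 1 to compound 2. It shortens the chain and keeps the imidazole, so it does not test the loss of that ring. Both measured compounds share (the limit of > 100000 nM in this assay, at which 2 of the 2 values shown sit), and the data therefore give no step size to carry over. In this assay, no step beyond the scatter is expected, and compound 3 may well report a limit too. The expected change is a number no higher from compound 2 to compound 3 (the limit leaves the size open). For compound 3, the estimated value is 100000 nM, with an expected range of 40000 nM to 250000 nM.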

Compound 3, half-maximal inhibitory concentration: > 100000 nM
Compound 3 ended at the assay's limit; the forecaster's own chance of this, stated with the estimate: 65%; the middle value lies on the limit itself.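

In this assay compound 3 gives > 100000 nM, which is a limit and not a number. No step among compound 1, compound 2 and compound 3 can therefore be read: the limit of > 100000 nM in this assay, at which 3 of the 3 values shown sit.

The compounds shown leave open whether replacing 1H-imidazol-1-yl with hydroxymethyl, or shortening the chain, has any effect on the read-out.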